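The source may hold more compounds than are shown below. What is called first, only, known or untested is meant among the compounds shown, and "the series" means these compounds.

The series shares one core carrying a cycloheptylamino group and a pyrrolidinylpiperidine, and is followed in an in vitro functional assay on B300-19 cells for antagonist activity at C-C chemokine receptor type 4 (Homo sapiens), read by GTPgammaS binding, tested at 1 uM; a higher number here means more inhibition at the concentration tested (going by the name of the read-out), a lower number less inhibition. Compound 1 `COc1ccc2c(NC3CCCCCC3)nc(N3CCC(N4CCCC4)CC3)nc2c1` gives 10% and compound 2 `c1ccc2c(NC3CCCCCC3)nc(N3CCC(N4CCCC4)CC3)nc2c1` gives 10%, so the step of no change at the digits printed from compound 1 to compound 2 (within the scatter) shows no change within the scatter. Compound 3 `CCNc1nc(N2CCC(N3CCCC3)CC2)nc2cc(OC)c(OC)cc12`, which carries two methoxy groups and an ethylamino group in place of the cycloheptylamino group, gives 3%. Compound 2 thus stands level with compound 1 at the digits shown, the pair being together the highest of the three numbers, while compound 3 differs from compound 2 by an amount that remains within the scatter. Compound 4 `COc1ccc2nc(N3CCC(N4CCCC4)CC3)nc(NC3CCCCCC3)c2c1` is the next compound to be read in this assay; from compound 2 the change is methoxy in place of hydrogen on an aromatic carbon. For the measured compounds named here, the only measured step that bears on it is the one from compound 1 to compound 2, where a methoxy group left without any change beyond the scatter, and compound 3 with its two methoxy groups also does not separate from the others beyond the scatter. A step of about no change at the digits printed from compound 2 to compound 4 (within the scatter) is therefore expected, none beyond the scatter. For compound 4 a value of 10% is estimated, with a range from 0% to 25%.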

Compound 4, a percentage reported as inhibition, at one concentration (the size of the read-out at that concentration, not a potency): 10%
Estimate against measurement, compound 4: no gap at the digits printed, and the stated range covers the measured number.
By their numbers in this assay, from the lowest: compounds 3, 1, 2 and 4 (each within the scatter of the next).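

In this assay, the step for methoxy in place of hydrogen, on the aromatic carbon that is meta to a fused ring and para to a fused ring, is no change at the digits printed from compound 2 to compound 4 (within the scatter). The earlier step concerned methoxy on a different aromatic carbon of the shared core, so a second placement is now covered: compound 1 gives 10% and compound 4 gives 10%, the same number at the digits printed. No supporting measurement is available to account for this flat result.

On these data alone, whether an amine, a carboxylic acid or a longer alkoxy chain on this same carbon would move the number beyond the scatter remains open. Also open, as far as these compounds go, is whether methoxy here would read the same on a compound of the series with a clearly higher number.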